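The source may hold more compounds than are shown below. What is called first, only, known or untested is meant among the compounds shown, and "the series" means these compounds.

Measured compounds:
Compound 1 `CC(=O)Nc1cccc(-c2ccc(C(=O)N(Cc3cccc(OCCCCCC(=O)O)c3)C(C)C)cc2)c1`: in an ADME assay on BJ cells (Homo sapiens) for cytotoxicity, read by CellTiter-Glo and resazurin assay, with a stated time of 72 h (on this read-out lower numbers stand for an effect already at smaller amounts and higher numbers for an effect only at larger amounts of compound), compound 1 reaches only the assay limit, > 26000 nM.
Compound 2 `CC(=O)c1cccc(-c2ccc(C(=O)N(Cc3cccc(OCCCCCC(=O)O)c3)C(C)C)cc2)c1`: in this assay compound 2 likewise reaches only the limit, > 26000 nM.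
Compound 3 `COc1cc(OC)cc(-c2ccc(C(=O)N(Cc3cccc(OCCCCCC(=O)O)c3)C(C)C)cc2)c1`: in this assay compound 3 also reaches only the limit, > 26000 nM.

All three measured compounds share one core and differ only in the aryl group at its end; none of them gives a number in this assay, since each sits at the same limit (the limit of > 26000 nM in this assay, at which 3 of the 3 values shown sit). The steps between them are therefore unreadable: a step that the two limits leave unreadable from compound 1 to compound 2, a step that the two limits leave unreadable from compound 1 to compound 3, and a step that the two limits leave unreadable from compound 2 to compound 3 show only that neither acetyl, acetamido nor dimethoxy substitution brought the effect inside the measured window. Compound 3 thus stands where the other two do, at the limit.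

Compound 4 `CC(C)N(Cc1cccc(OCCCCCC(=O)O)c1)C(=O)c1ccc(-c2cccc(O)c2)cc1` is not yet measured. It differs from compound 3 by 3-hydroxyphenyl in place of 3,5-dimethoxyphenyl on an aromatic carbon. No measured step bears readably on this change, as all three shown values are limits. Given that every aryl variant so far, compound 1, compound 2 and compound 3, stayed at the limit (the limit of > 26000 nM in this assay, at which 3 of the 3 values shown sit), compound 4 is expected to stay there too, with no step beyond the scatter, a step that the limit leaves unreadable from compound 3 to compound 4. The estimate for compound 4 is 40000 nM, with a range from 18000 nM to 120000 nM.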

Compound 4, half-maximal effective concentration: > 26000 nM
Compound 4: a limit, no number; the forecaster's own chance of this, stated with the estimate: 85%; the middle value lies beyond the limit too.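

In this assay compound 4 also reaches only a limit, > 26000 nM. Its steps to compound 1, compound 2 and compound 3 therefore cannot be read: the limit of > 26000 nM in this assay, at which 4 of the 4 values shown sit. The compounds shown leave open at what concentration, if any, these four compounds would show an effect.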